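Methylsulfonyl for Methylcarbamoyl: Expecting the Half-Life of Compound 4

The source may report more compounds than this note shows. Statements on the series, on what has been measured and on what is new or still open speak of the compounds shown alone.

Three compounds share one core. In an ADME assay on microsomes from liver (Rattus norvegicus) for metabolic stability (on this read-out higher numbers stand for a longer-lived compound and lower numbers for a shorter-lived compound), compound 1 `COc1cc(OCc2cccc(-c3ccc(C#N)cc3)c2)c2cc(-c3cn4nc(OC)sc4n3)oc2c1` gives 1.67 h, compound 2 `COc1cc(OCc2cccc(-c3ccc(OC)nc3)c2)c2cc(-c3cn4nc(OC)sc4n3)oc2c1` gives 0.633 h, and compound 3 `CNC(=O)c1ccc(-c2nc(COc3cc(OC)cc4oc(-c5cn6nc(OC)sc6n5)cc34)cs2)cc1` gives 0.517 h. Compound 3 lies within the scatter of compound 2 and beyond the scatter below compound 1. Among the measured compounds shown here, the only measured step, a 2.6-fold lower number from compound 1 to compound 2 (0.42 log units; beyond the scatter), concerns a different change of an aryl ring. Compound 4 `COc1cc(OCc2csc(-c3ccc(S(C)(=O)=O)cc3)n2)c2cc(-c3cn4nc(OC)sc4n3)oc2c1` differs from compound 3 by methylsulfonyl in place of methylcarbamoyl on an aromatic carbon. For the measured compounds named here, no measured step bears on this change, so in this assay the expectation is a step not beyond the scatter, which the estimated 1.0-fold lower number from compound 3 to compound 4 (0.01 log units; within the scatter) expresses. Compound 4 is therefore expected to give about 0.5 h, with a range from 0.25 h to 1 h.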

Compound 4, half-life: 1.12 h
The estimate for compound 4 lay 2.2-fold (0.35 log units) below the measured number, outside the stated range (above it).
By their numbers in this assay, from the lowest: compounds 3, 2, 4 and 1 (each within the scatter of the next, the first and the last beyond it).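

In this assay, among the compounds shown here, the step of a 2.2-fold higher number from compound 3 to compound 4 (0.34 log units; beyond the scatter) is the first measured change of the group on this six-membered aromatic ring of carbon only. It shows that the position responds to the group it carries, since methylsulfonyl in place of methylcarbamoyl moves the half-life beyond the scatter. Nothing measured here accounts for the step. From the compounds shown here alone, whether other groups at this position, such as an amine or a carboxylic acid, would give a longer or a shorter half-life remains open. So does whether the same exchange would give a similar step on another scaffold.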